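Methoxy in place of trifluoromethyl on the aryl ring

The source may hold more compounds than are shown below. What is called first, only, known or untested is meant among the compounds shown, and "the series" means these compounds.

Measured compounds:
Compound 1, `CC(=O)N1CC[C@H](c2ccc(F)cc2)[C@@H]1C(=O)N1CCN(c2ccc(C)cc2[C@@H](N)C(C)C)CC1`: 330 nM
Compound 2, `CC(=O)N1CC[C@H](c2ccc(C(F)(F)F)cc2)[C@@H]1C(=O)N1CCN(c2ccc(C)cc2[C@@H](N)C(C)C)CC1`: 54 nM
Compound 3, `CCOC(=O)N1CC[C@H](c2ccc(Cl)cc2)[C@@H]1C(=O)N1CCN(c2ccc(C)cc2[C@@H](N)C(C)C)CC1`: 11 nM; 16 nM (2 entries)

In an assay on HEK293 cells for displacement of a labelled ligand from Melanocortin receptor 4 (Homo sapiens) (a higher number here means a weaker inhibitor, a lower number a stronger inhibitor), compound 2 has the lowest of the two single numbers, with compound 1 the nearest at a 6.1-fold lower number from compound 1 to compound 2 (0.79 log units; beyond the scatter). Compound 3 has several entries (the several entries of compound 3 in this assay, 11 nM; 16 nM (2 entries)) and differs from compound 2 in two places, so its values are noted but not compared as a single step.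

Compound 4, `COc1ccc([C@H]2CCN(C(C)=O)[C@H]2C(=O)N2CCN(c3ccc(C)cc3[C@@H](N)C(C)C)CC2)cc1`, is to be measured in this assay. It differs from compound 2 by methoxy in place of trifluoromethyl on an aromatic carbon. For the measured compounds named here, the only measured step at this position is a 6.1-fold lower number from compound 1 to compound 2 (0.79 log units; beyond the scatter), where the four-heavy-atom trifluoromethyl in place of fluoro gave a lower number beyond the scatter. Compound 4 now removes that trifluoromethyl and puts a two-heavy-atom methoxy in its place, so the step is expected to run the other way, with a higher number than compound 2, of moderate size: the expected step is a 3.0-fold higher number from compound 2 to compound 4 (0.47 log units; beyond the scatter). Compound 4 is estimated at 160 nM, between 50 nM and 500 nM.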

Compound 4, inhibition constant: 45 nM
Estimate against measurement, compound 4: 3.6-fold (0.55 log units) above; the whole stated range lies above it.
By their numbers in this assay, from the lowest: compounds 4 and 2 (each within the scatter of the next); then compound 1.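

In this assay, for the compounds shown here, the earlier compounds showed only that this position responds to a change of group; the change from 4-(trifluoromethyl)phenyl to 4-methoxyphenyl now gives a 1.2-fold lower number from compound 2 to compound 4 (0.08 log units; within the scatter), so two groups that differ in heavy atoms and in hydrogen-bond acceptors cannot be told apart here. Measured against fluoro, methoxy gives a 7.3-fold lower number from compound 1 to compound 4 (0.87 log units; beyond the scatter), a step of similar size to a 6.1-fold lower number from compound 1 to compound 2 (0.79 log units; beyond the scatter), so among these compounds the advantage over compound 1 does not belong to trifluoromethyl alone. Nothing shown gives a cause for this result.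

The compounds shown leave open how an amine or a carboxylic acid on this aromatic carbon would fare. They also leave open whether a longer chain on the oxygen of the methoxy group would hold the level of compound 2 and compound 4.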